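Lengthening the Chain Toward the Oxane Ring

This account rests on a few compounds, and the source may have more. Where it says the series, first, only, none or still open, it means among the compounds named here.

The account begins with compound 1 `CC(C)(O)c1ccc(-c2cnc3c(n2)N(CC2CCOCC2)C(=O)CN3)cn1`, for which an ADME assay on the whole organism for pharmacokinetics, with Rattus norvegicus as the target, at a dose of 2 mg/kg by the intravenous route (a higher number here means faster removal of the compound, a lower number slower removal), gives "not determined" (no result reported), so it stands on no number of its own. Two related compounds do carry values. Compound 2 `CO[C@H]1CC[C@H](N2CC(=O)Nc3ncc(-c4ccc(C(C)(C)O)nc4)nc32)CC1` shares the dimethylcarbinol-bearing pyridine with compound 1. In this assay compound 2 gives 1.7 mL/min/kg. Compound 3 `O=c1[nH]c2ncc(-c3ccc(-c4nc[nH]n4)cc3)nc2n1CCC1CCOCC1`, which carries the 2-(oxan-4-yl)ethyl chain on a different core, gives 32 mL/min/kg in this assay. Those two numbers are the whole of what has been measured here.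

Compound 4 `CC(C)(O)c1ccc(-c2cnc3c(n2)N(CCC2CCOCC2)C(=O)CN3)cn1` is the untested partner of compound 1. The change between them is (oxan-4-yl)methyl in place of oxan-4-yl on a saturated chain carbon bound to an amide-type nitrogen in a ring. Since the step from compound 1 cannot be measured against a starting number, the size of its effect in this assay is not expected to be readable beyond the scatter, and the estimate rests on the spread between compound 2 and compound 3. Compound 4 is therefore expected to show a clearance of about 10 mL/min/kg, with a plausible range from 3 mL/min/kg to 30 mL/min/kg.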

Compound 4, clearance: 9 mL/min/kg
Estimate against measurement, compound 4: 1.1-fold (0.05 log units) above; low and high end bracket the measured number.
By their numbers in this assay, from the lowest: compound 2; then compound 4; then compound 3.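

In this assay no step can be read between compound 1 and compound 4. The compounds shown leave open what the change from oxan-4-yl to (oxan-4-yl)methyl does to clearance on the shared core. Nothing measured here accounts for the result for compound 4.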